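The compounds below may be only part of what the source reports. "The series", "measured", "known", "first", "only" and "open" are said of these compounds alone.

Working notes on the cytotoxicity series. In an ADME assay on Vero cells (Chlorocebus sabaeus) for cytotoxicity (on this read-out higher numbers stand for lower toxicity in this test and lower numbers for higher toxicity in this test), compound 1, `CN1CCN(CC(=O)Nc2ccc(-c3nc4cc(Cl)c(Cl)cc4[nH]3)cc2)CC1`, gives > 100000 nM, which is a limit of the assay and not a number. Compound 2, `CN1CCN(CC(=O)Nc2ccc(-c3nc4cc(C(F)(F)F)ccc4n3C)cc2)CC1`, gives > 100000 nM in this assay, again a limit rather than a number. Compound 2 therefore sits at the limit of > 100000 nM in this assay, at which 2 of the 2 values shown sit; no order between the two measured compounds can be read from these limits. Compound 3, `CC(=O)Nc1ccc(-c2nc3cc(C(F)(F)F)ccc3n2C)cc1`, is still to be measured in this assay. It differs from compound 2 by hydrogen in place of 4-methylpiperazin-1-yl on a saturated chain carbon bound to a carbonyl carbon. Among the compounds with values here, no step between measured compounds is available to size this change. The expected step in this assay is a number no higher from compound 2 to compound 3 (the limit leaves the size open), that is, none beyond the scatter, with the value again likely to come back as a limit. Compound 3 is accordingly estimated at 100000 nM, within 30000 nM to 300000 nM.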

Compound 3, half-maximal cytotoxic concentration: > 100000 nM
Compound 3: no number, only a limit; the forecaster's own chance of this, stated with the estimate: 70%; the middle value sits exactly at the limit.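

The step from compound 2 to compound 3 in this assay cannot be read, as both results are limits of the assay and not numbers. The compounds shown leave open whether hydrogen in place of 4-methylpiperazin-1-yl changes the read-out at all, and they give no order among themselves: the limit of > 100000 nM in this assay, at which 3 of the 3 values shown sit.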